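A few compounds are considered here, and "the series" means these few. Any claim that something is new, unique, unknown or untested is made for them only; others in the source may bear on it.

Measured in a physicochemical assay for solubility, measured as kinetic solubility, at pH 2; a lower number here means a less soluble compound, a higher number a more soluble compound:

- Compound 1 `O=C1NC(=O)/C(=C/C(c2ccc(-c3ccc4cccc(F)c4c3)[nH]c2=O)C2CC2)O1`: 3850 nM
- Compound 2 `O=C1NC(=O)/C(=C/C(c2ccccc2)c2ccc(-c3ccc4cccc(F)c4c3)[nH]c2=O)O1`: 15400 nM

Compound 2, at 15400 nM, holds the higher of the two numbers in this assay, and compound 1 gives 3850 nM. The next compound to be measured is compound 3 `O=C1NC(=O)/C(=C/C(Cc2ccccc2)c2ccc(-c3ccc4cccc(F)c4c3)[nH]c2=O)O1`, which keeps the shared core of compound 2 and changes one group: benzyl in place of phenyl on a saturated chain carbon bound to an aromatic carbon and a double-bonded chain carbon. Going by the values given here, only one measured step bears on this place, namely a 4.0-fold higher number from compound 1 to compound 2 (0.60 log units; beyond the scatter), with phenyl in place of cyclopropyl. That step shows that the number can move beyond the scatter when the group at this place changes, but it is modest. Among the compounds with values here, it does not show what benzyl does, as no measured pair has phenyl and benzyl as its two groups. A step no larger than that one is therefore expected, with a slight lean towards a lower number. The estimated change is a 1.5-fold lower number from compound 2 to compound 3 (0.19 log units; within the scatter). For compound 3 the expected value is 10000 nM, with an estimated range from 3500 nM to 25000 nM.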

Compound 3, solubility: 900 nM
Compound 3: the middle estimate sits 11-fold (1.05 log units) above what was measured; measured number outside the range, below it.
By their numbers in this assay, from the lowest: compound 3; then compound 1; then compound 2.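

In this assay, going by these compounds alone, the saturated chain carbon bound to an aromatic carbon and a double-bonded chain carbon proves more sensitive than the one earlier step could show: benzyl in place of phenyl gives a 17-fold lower number from compound 2 to compound 3 (1.23 log units; beyond the scatter), a large step. The change is small on paper, from 6 heavy atoms to 7, and both groups have one six-membered aromatic ring of carbon only, so among these compounds the presence of that ring does not settle the number. Benzyl also falls under cyclopropyl, with a 4.3-fold lower number from compound 1 to compound 3 (0.63 log units; beyond the scatter), which places cyclopropyl in the middle of the three and the two ring-bearing groups at the two ends. Nothing measured here accounts for the size of this step.

The three compounds leave open whether a longer chain ending in the same ring would carry the number further down or whether the step stops at benzyl. They also leave open what an amine or a carboxylic acid on the benzyl ring would do at this place, and whether the step between phenyl and benzyl holds on any other core.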